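The compounds below may be only part of what the source reports. "The series", "measured", "known", "first", "only" and "open" are said of these compounds alone.

Compound 3, `O=C(O)CCc1ccc(OCc2nc(-c3ccc(Cl)cc3)no2)cc1`, gives 540 nM in a functional assay on CHO cells for agonist activity at Free fatty acid receptor 1 (Homo sapiens), read by FLIPR and calcium flux, in the presence of a further agent that is not named here (a higher number here means that more compound is needed for the effect, a lower number that less compound is needed), the lowest of the three numbers measured. Compound 1, `O=C(O)CCc1ccc(OCc2nc(-c3ccccc3)no2)cc1`, gives 1130 nM, and compound 2, `O=C(O)CCc1ccc(OCc2nc(-c3cccs3)no2)cc1`, gives 2570 nM. The step of a 2.1-fold lower number from compound 1 to compound 3 (0.32 log units; beyond the scatter) came from chloro in place of hydrogen on an aromatic carbon; the step of a 4.8-fold lower number from compound 2 to compound 3 (0.68 log units; beyond the scatter) from 4-chlorophenyl in place of thiophen-2-yl; the step of a 2.3-fold higher number from compound 1 to compound 2 (0.36 log units; beyond the scatter) from thiophen-2-yl in place of phenyl.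

Compound 4, `O=C(O)CCc1ccc(OCc2nc(-c3ccc(F)cc3)no2)cc1`, differs from compound 3 by fluoro in place of chloro on an aromatic carbon. For the measured compounds named here, only one measured step touches this position, the modest step of a 2.1-fold lower number from compound 1 to compound 3 (0.32 log units; beyond the scatter), where hydrogen became chloro. Fluoro is a different substituent at the same place, and no measured compound shows its effect directly. The expected step of a 1.5-fold higher number from compound 3 to compound 4 (0.17 log units; within the scatter) is therefore small, most likely a somewhat higher number than compound 3 without returning fully to compound 1. Compound 4 is estimated at 800 nM, within a range from 400 nM to 1600 nM.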

Compound 4, half-maximal effective concentration: 680 nM
Compound 4: middle estimate off by 1.2-fold (0.07 log units), on the high side, within the range that was stated.
By their numbers in this assay, from the lowest: compounds 3, 4 and 1 (each within the scatter of the next, the first and the last beyond it); then compound 2.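

In this assay, fluoro and chloro at this place on the phenyl ring cannot be told apart, with a 1.3-fold higher number from compound 3 to compound 4 (0.10 log units; within the scatter). The earlier compounds shown here showed that chloro in place of hydrogen gives a step beyond the scatter, whereas fluoro in place of hydrogen does not, with a 1.7-fold lower number from compound 1 to compound 4 (0.22 log units; within the scatter), although the fluoro and chloro compounds themselves stay within the scatter of each other. The 4-fluorophenyl group, like 4-chlorophenyl, remains clearly apart from thiophen-2-yl, with a 3.8-fold lower number from compound 2 to compound 4 (0.58 log units; beyond the scatter), and nothing available here explains any of these steps.

Open, going by these compounds, is how other groups at this place, such as bromo, methoxy, trifluoromethyl or an amine, would compare with these two halogens. Also open, on these data alone, is whether chloro or fluoro on the thiophen-2-yl ring would give a similar step.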